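A few compounds are considered here, and "the series" means these few. Any claim that something is new, unique, unknown or untested is made for them only; others in the source may bear on it.

Three measured compounds share one core. In a functional assay on DU-145 cells (Homo sapiens) for inhibition, read by trypan blue exclusion, with a stated time of 96 h (on this read-out higher numbers stand for weaker inhibition of growth and lower numbers for stronger inhibition of growth), compound 1 `Cc1ccsc1/C=C(/SCc1ccc(F)cc1)C(=O)c1ccc(Br)cc1` gives 50000 nM. Compound 2 `Cc1ccsc1/C=C(/SCc1ccc(F)cc1)C(=O)c1ccc(Cl)cc1` gives 50000 nM; the change of chloro in place of bromo on an aromatic carbon brought no change at the digits printed from compound 1 to compound 2 (within the scatter). Compound 3 `Cc1ccsc1/C=C(/SCc1ccc(Cl)cc1Cl)C(=O)c1ccc(Cl)cc1` gives 10000 nM; the change of 2,4-dichlorophenyl in place of 4-fluorophenyl on a saturated chain carbon bound to a sulfur brought a 5.0-fold lower number from compound 2 to compound 3 (0.70 log units; beyond the scatter). Compound 2 therefore stands level with compound 1, the two together at the highest number of the three, and only compound 3 is set apart from them.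

Compound 4 `CN(C)c1ccc(/C=C(/SCc2ccc(F)cc2)C(=O)c2ccc(Cl)cc2)cc1` has not yet been measured. It differs from compound 2 in 4-(dimethylamino)phenyl in place of 3-methylthiophen-2-yl on a double-bonded chain carbon bound to a double-bonded chain carbon. Neither measured step touches this part of the core: one alters a halogen on an aromatic carbon, the other the group on the saturated chain carbon bound to a sulfur. Among the measured compounds shown here, no measured step gives a direction for this change, so the expectation rests on compound 2 alone and carries wide uncertainty. Compound 4 is expected to give about 25000 nM, with a likely range of 6000 nM to 60000 nM. The step of a 2.0-fold lower number from compound 2 to compound 4 (0.30 log units; within the scatter) is expected to stay near the edge of the scatter.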

Compound 4, concentration for 50% growth inhibition: 50000 nM
The estimate for compound 4 lay 2.0-fold (0.30 log units) below the measured number; measured number inside the range.
By their numbers in this assay, from the lowest: compound 3; then compounds 1, 2 and 4 (each within the scatter of the next).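

In this assay, replacing the five-membered sulfur-containing ring with a six-membered carbon ring at this position brought no change at the digits printed from compound 2 to compound 4 (within the scatter), even though 4-(dimethylamino)phenyl has 9 heavy atoms where 3-methylthiophen-2-yl has 6. Among the compounds shown here, this is the first look at the double-bonded chain carbon, and here neither the ring type nor the added dimethylamino group moved the number beyond the scatter. No measurement is available to explain this result.

On these data alone, it remains open whether the same exchange would also leave the number in place when the 2,4-dichlorophenyl group of compound 3 is present. The compounds shown also leave open how a plain phenyl ring, or a phenyl ring carrying a carboxylic acid, would behave on this same carbon.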